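Replacing furan with oxolane on the amine arm

The source may hold more compounds than are shown below. What is called first, only, known or untested is meant among the compounds shown, and "the series" means these compounds.

Compound 3 `Clc1nc(NCc2ccco2)c2ncn(C3CCCO3)c2n1` was examined in an ADME assay on NHDF cells (Homo sapiens) for cytotoxicity, read by neutral red uptake, with a stated time of 24 h, tested at 125 uM; on this read-out higher numbers stand for a stronger effect at the one concentration tested and lower numbers for a weaker effect. In this assay compound 3 gives 101%, a number that sits alongside compound 1 `c1csc(CNc2ncnc3c2ncn3C2CCCO2)c1` with 108% and compound 2 `OCc1ccc(CNc2ncnc3c2ncn3C2CCCO2)o1` with 110%, all three within the usual scatter of one another. Compound 4 `Clc1nc(NCC2CCCO2)c2ncn(C3CCCO3)c2n1` is not yet measured; it differs from compound 3 in one place: oxolan-2-yl in place of furan-2-yl on a saturated chain carbon bound to a nitrogen on an aromatic ring. For the measured compounds named here, the only measured step at that same place, a number 2 percentage points higher from compound 1 to compound 2 (within the scatter), swapped one aromatic ring for another and produced no change beyond the scatter. On that basis no step beyond the scatter is expected, and compound 4 is estimated at 103% (range 90% to 116%), an expected step of a number 2 percentage points higher from compound 3 to compound 4 (within the scatter).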

Compound 4, a percentage reported as activity, at one concentration (the size of the read-out at that concentration, not a potency): 104%
Estimate against measurement, compound 4: 1 percentage points below; the measured number falls inside the stated range.
By their numbers in this assay, from the lowest: compounds 3, 4, 1 and 2 (each within the scatter of the next).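

The earlier step only exchanged one aromatic ring for another, whereas this change replaces an aromatic ring with a non-aromatic one of the same heavy-atom count, and this assay gives a number 3 percentage points higher from compound 3 to compound 4 (within the scatter). At this place, on a saturated chain carbon bound to a nitrogen on an aromatic ring, losing the aromatic ring therefore moves the number no further than the scatter, at least in this one pair. No measured evidence is available to explain this result. Still open, on these data alone, is whether an amine or a carboxylic acid in place of the ring, or a longer chain, would shift the number beyond the scatter.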